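The source may report more compounds than this note shows. Statements on the series, on what has been measured and on what is new or still open speak of the compounds shown alone.

Measured compounds:
compound 1, `C=C1CC[C@@H]2[C@](C)(COC(C)=O)[C@H](OC(C)=O)CC[C@@]2(C)[C@H]1CC(Nc1ccc(S(=O)(=O)Nc2nccc(C)n2)cc1)C1=CCOC1=O`, in a functional assay on UACC-62 cells (Homo sapiens) for inhibition, read by sulforhodamine B assay, with a stated time of 48 h (a higher number here means a weaker inhibitor of growth, a lower number a stronger inhibitor of growth), compound 1 gives 2380 nM.
compound 2, `C=C1CC[C@@H]2[C@](C)(COC(C)=O)[C@H](OC(C)=O)CC[C@@]2(C)[C@H]1CC(Nc1ccc(S(=O)(=O)Nc2nccs2)cc1)C1=CCOC1=O`, in this assay compound 2 gives 1760 nM.

Both compounds share one core and differ only in the ring on the sulfonamide nitrogen. Among the compounds with values here, the single measured step, a 1.4-fold lower number from compound 1 to compound 2 (0.13 log units; within the scatter), is within the scatter, so compound 2 and compound 1 cannot be told apart on these numbers.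

Compound 3, `C=C1CC[C@@H]2[C@](C)(COC(C)=O)[C@H](OC(C)=O)CC[C@@]2(C)[C@H]1CC(Nc1ccc(S(=O)(=O)Nc2ncccn2)cc1)C1=CCOC1=O`, is not yet measured. Its change from compound 2 is pyrimidin-2-yl in place of 1,3-thiazol-2-yl on a sulfonamide nitrogen. The entering ring is the ring of compound 1 without its methyl group, so compound 3 sits between the two measured compounds in structure. Within the data shown here, the only step that bears on it is a 1.4-fold lower number from compound 1 to compound 2 (0.13 log units; within the scatter), and it showed no effect beyond the scatter. The step of a 1.1-fold higher number from compound 2 to compound 3 (0.06 log units; within the scatter) is therefore expected to stay within the scatter, in no particular direction. Compound 3 is estimated at 2000 nM, with a range from 1000 nM to 4000 nM.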

Compound 3, concentration for 50% growth inhibition: 1110 nM
Compound 3: middle estimate off by 1.8-fold (0.26 log units), on the high side; low and high end bracket the measured number.
By their numbers in this assay, from the lowest: compounds 3, 2 and 1 (each within the scatter of the next, the first and the last beyond it).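

In this assay, within the data shown here, the step of a 2.1-fold lower number from compound 1 to compound 3 (0.33 log units; beyond the scatter) is the first in this set to pass the scatter, though only modestly, and it comes from the smallest change here: hydrogen in place of methyl on an aromatic carbon of the ring on the sulfonamide nitrogen. By contrast, the step of a 1.6-fold lower number from compound 2 to compound 3 (0.20 log units; within the scatter) stays within the scatter, so this position shows no readable difference between the five-membered 1,3-thiazol-2-yl ring and the six-membered pyrimidin-2-yl ring. No measurement shown here explains either result.

Going by these compounds, it remains open whether a methoxy group or a chlorine on the pyrimidin-2-yl ring would act as methyl does. On these data alone, it is also open whether this position needs an aromatic ring at all, as a phenyl ring, an acetyl group or plain hydrogen on the sulfonamide nitrogen would test.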